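Triazole aryl variation in the uracil sulfonamide series

The source may report more compounds than this note shows. Statements on the series, on what has been measured and on what is new or still open speak of the compounds shown alone.

compound 1 `O=c1[nH]cc(S(=O)(=O)Nc2cccc(-c3cn(-c4ccccc4)nn3)c2)c(=O)[nH]1` — in a functional assay on SGC-7901 cells (Homo sapiens) for antiproliferative activity, read by MTT assay, with a stated time of 24 h (a lower number here means a stronger inhibitor, a higher number a weaker inhibitor), compound 1 gives 17200 nM
compound 2 `Cc1ccc(-n2cc(-c3cccc(NS(=O)(=O)c4c[nH]c(=O)[nH]c4=O)c3)nn2)cc1` — in this assay compound 2 gives 9430 nM
compound 3 `O=c1[nH]cc(S(=O)(=O)Nc2cccc(-c3cn(-c4ccc(F)cc4)nn3)c2)c(=O)[nH]1` — in this assay compound 3 gives only a limit of the assay, > 20000 nM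

Compound 3 sits at the limit of > 20000 nM in this assay, at which 1 of the 3 values shown sits; no number is known for it, only that it lies at or past the ceiling of the measurement. The three measured steps all change one group on the same aromatic carbon of the ring attached to the triazole nitrogen: a 1.8-fold lower number from compound 1 to compound 2 (0.26 log units; within the scatter), an at least 1.1-fold higher number from compound 1 to compound 3 (0.06 log units; that floor lies within the scatter) and an at least 2.1-fold higher number from compound 2 to compound 3 (0.32 log units; beyond the scatter). Of these only the last clears the scatter, and it ends at the limit, so its true size is open.

Compound 4 `O=c1[nH]cc(S(=O)(=O)Nc2cccc(-c3cn(-c4ccccc4Cl)nn3)c2)c(=O)[nH]1` differs from compound 3 by 2-chlorophenyl in place of 4-fluorophenyl on an aromatic nitrogen. For the measured compounds named here, none of the measured steps involves a chloro group or a substituent at this position of the aryl ring, so they bear on the change only loosely: they show that small changes on this ring move the number little, with compound 3 the weakest point reached. Compound 4 is therefore expected near 20000 nM, in a range from 6000 nM to 60000 nM. The step of a number no higher from compound 3 to compound 4 (the limit leaves the size open) is expected to stay within the scatter, with a real chance that only a limit is reported again.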

Compound 4, half-maximal inhibitory concentration: 3010 nM
Estimate against measurement, compound 4: 6.6-fold (0.82 log units) above; measured number outside the range, below it.
By their numbers in this assay, from the lowest: compound 4; then compounds 2 and 1 (each within the scatter of the next). At a limit, above all of these: compound 3.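

For the compounds shown here, the aryl group on the aromatic nitrogen can lower the number in this assay beyond the scatter, which no earlier step on this ring did: replacing hydrogen with chloro gives a 5.7-fold lower number from compound 1 to compound 4 (0.76 log units; beyond the scatter). Compound 4 is also clearly separated from the methyl-bearing compound, with a 3.1-fold lower number from compound 2 to compound 4 (0.50 log units; beyond the scatter), and is the strongest of the compounds shown. The change from 4-fluorophenyl to 2-chlorophenyl gives an at least 6.6-fold lower number from compound 3 to compound 4 (0.82 log units; beyond the scatter), but that size is only a floor, and compound 3 remains a limit of the assay rather than a number: the limit of > 20000 nM in this assay, at which 1 of the 4 values shown sits.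

Compound 4 alone carries chloro and alone has its substituent at this place on the ring, so the compounds shown do not separate the effect of the group from that of its place. Also open, on these data alone, is whether a methoxy group, an amine or a carboxylic acid on this aryl ring would keep, lose or extend the gain seen with 2-chlorophenyl.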